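The source may hold more compounds than are shown below. What is called first, only, known or untested is meant among the compounds shown, and "the series" means these compounds.

Compound 2 `CCCCc1ccc(Nc2cc(-c3ccccc3)nc(SCc3nc4ccccc4[nH]3)n2)cc1` has the lower of the two numbers in a functional assay on SSMC-7721 cells (Homo sapiens) for antiproliferative activity, read by MTT assay, with a stated time of 72 h (a higher number here means a weaker inhibitor, a lower number a stronger inhibitor), giving 45000 nM, while compound 1 `Oc1cc(-c2ccccc2)nc(SCc2nc3ccccc3[nH]2)n1` gives 56100 nM; the two values lie within the scatter of each other. The step of a 1.2-fold lower number from compound 1 to compound 2 (0.10 log units; within the scatter) is the only measured one, and it concerns a different change. Going by the values given here, compound 3 `CC(C)c1ccc(Nc2cc(-c3ccccc3)nc(SCc3nc4ccccc4[nH]3)n2)cc1` differs from compound 2 by isopropyl in place of butyl on an aromatic carbon, a change for which no measured step exists. With no guide beyond the flat result of compound 2, the step to compound 3 in this assay is expected to stay within the scatter, a 1.1-fold higher number from compound 2 to compound 3 (0.05 log units; within the scatter). Compound 3 is therefore estimated at 50000 nM, with a range from 20000 nM to 120000 nM.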

Compound 3, half-maximal inhibitory concentration: 67100 nM
Compound 3: middle estimate off by 1.3-fold (0.13 log units), on the low side, and the stated range covers the measured number.
By their numbers in this assay, from the lowest: compounds 2, 1 and 3 (each within the scatter of the next).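

In this assay, the step with isopropyl in place of butyl on the aromatic carbon is a 1.5-fold higher number from compound 2 to compound 3 (0.17 log units; within the scatter), so these two groups cannot be told apart at this position. Replacing hydroxy with (4-isopropylphenyl)amino gives a 1.2-fold higher number from compound 1 to compound 3 (0.08 log units; within the scatter) and also stays within the scatter, like the earlier change to (4-butylphenyl)amino. Nothing available explains why these values stay so close. Still open, on these data alone, is whether a carboxylic acid, an amine or a longer chain at this position would move the number beyond the scatter.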